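The source may report more compounds than this note shows. Statements on the series, on what has been measured and on what is new or still open speak of the compounds shown alone.

Compound 1, with structure `O=S(=O)(NC[C@H](O)CN1CCCC1)c1cccc2ccccc12`, is the starting point here. In an assay on HEK293 cells for inhibition of sodium- and chloride-dependent glycine transporter 1 (Homo sapiens) (a lower number here means a stronger inhibitor, a higher number a weaker inhibitor), compound 1 gives 3160 nM, which is the only number shown for it; a further reading exists without a single number. Compound 2, with structure `CC(C)C1CCCN1C[C@@H](O)CNS(=O)(=O)c1cccc2ccccc12`, carries an extra branch on the same five-membered ring and gives 200 nM; 1000 nM (2 entries) in this assay, the spread of those entries being seen in the several entries of compound 2 in this assay, 200 nM; 1000 nM (2 entries). Compound 3, with structure `CC[C@H]1CCCCN1C[C@@H](O)CNS(=O)(=O)c1cccc2ccccc12`, is not yet measured. It differs from compound 1 in one place: 2-ethylpiperidin-1-yl in place of pyrrolidin-1-yl on a saturated chain carbon, two bonds along the chain from an oxygen on a saturated carbon. Since compound 2 shows that a branched ring at this position sits well below compound 1 in this assay, the step of a 6.3-fold lower number from compound 1 to compound 3 (0.80 log units; beyond the scatter) is expected to bring a clearly stronger inhibitor, beyond the usual scatter. Compound 3 is therefore estimated at 500 nM, within a range from 150 nM to 2000 nM.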

Compound 3, half-maximal inhibitory concentration: 100 nM
Compound 3: middle estimate off by 5.0-fold (0.70 log units), on the high side; the whole stated range lies above it.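

In this assay the change to 2-ethylpiperidin-1-yl brings a 32-fold lower number from compound 1 to compound 3 (1.50 log units; beyond the scatter), so this place on the chain accepts a larger ring with a side branch. The earlier compounds shown here showed only a branch added to the five-membered ring, whereas compound 3 shows that a six-membered ring bearing an ethyl branch also gives a much lower number. Some care is needed with the exact size of this step, since a single reading stands for compound 3 and a related compound with a branched ring gave quite different readings: the several entries of compound 2 in this assay, 200 nM; 1000 nM (2 entries)

Ring size and the ethyl branch change together here, so their separate shares in the step cannot be told apart. As far as these compounds go, how a plain piperidin-1-yl, a 2-methylpiperidin-1-yl or a morpholin-4-yl would read at this place remains open, as does the mirror-image form of the 2-ethylpiperidin-1-yl group.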